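Five-membered heteroaryl replacements on a salicylic acid core

The source may hold more compounds than are shown below. What is called first, only, known or untested is meant among the compounds shown, and "the series" means these compounds.

Measured so far:
compound 1, `O=C(O)c1cc(-n2cccc2)ccc1O`, 50 mg/kg
compound 3, `O=C(O)c1cc(-c2ncc[nH]2)ccc1O`, 200 mg/kg
compound 2, `O=C(O)c1cc(-c2nccs2)ccc1O`, > 250 mg/kg (a limit of the assay)

Compound 3 carries the higher of the two numbers obtained in a functional assay on the whole organism for inhibition, with Rattus norvegicus as the target, read by paw edema; a lower number here means that less compound is needed, a higher number that more compound is needed for the effect; compound 1 sits below it by a 4.0-fold higher number from compound 1 to compound 3 (0.60 log units; beyond the scatter). For compound 2 this assay gave only a limit, (the limit of > 250 mg/kg in this assay, at which 1 of the 3 values shown sits), so that step an at least 1.2-fold lower number from compound 2 to compound 3 (0.09 log units; that floor lies within the scatter) is a floor within the scatter. Compound 4, `O=C(O)c1cc(-n2cncn2)ccc1O`, differs from compound 3 by 1H-1,2,4-triazol-1-yl in place of 1H-imidazol-2-yl on an aromatic carbon. Like compound 1, compound 4 joins the ring through nitrogen, which is the one measured step pointing to a lower number; compound 2 gives no guide. A modest step downward, a 1.7-fold lower number from compound 3 to compound 4 (0.22 log units; within the scatter), is therefore expected, with compound 4 estimated at 120 mg/kg (50 mg/kg to 250 mg/kg).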

Compound 4, dose for half-maximal effect: 200 mg/kg
For compound 4 the middle estimate is 1.7-fold (0.22 log units) below the measured one, within the range that was stated.
By their numbers in this assay, from the lowest: compound 1; then compounds 3 and 4 (each within the scatter of the next). At a limit, above all of these: compound 2.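

At this position, para to a hydroxy group, joining the ring through nitrogen does not by itself bring the lower number seen for compound 1: in this assay there is a 4.0-fold higher number from compound 1 to compound 4 (0.60 log units; beyond the scatter). Putting 1H-1,2,4-triazol-1-yl in place of 1H-imidazol-2-yl, which changes the linking atom and the hetero atom count, leaves no change at the digits printed from compound 3 to compound 4 (within the scatter). The remaining step, an at least 1.2-fold lower number from compound 2 to compound 4 (0.09 log units; that floor lies within the scatter), cannot be read, since its starting value is a limit: the limit of > 250 mg/kg in this assay, at which 1 of the 4 values shown sits.

As far as these compounds go, whether the gap to compound 1 follows the ring nitrogens stays open. A 1H-pyrazol-1-yl or 1H-imidazol-1-yl group at this position would test that.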